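Swapping the aryl group on the aromatic nitrogen

A few compounds are considered here, and "the series" means these few. Any claim that something is new, unique, unknown or untested is made for them only; others in the source may bear on it.

Compound 1 (`O=C(NO)c1ccc(NCc2nc(-c3ccccc3)nn2-c2ccc(F)cc2)cc1`) gives 10500 nM in a functional assay on MGC-803 cells (Homo sapiens) for antiproliferative activity, read by MTT assay, with a stated time of 72 h (on this read-out lower numbers stand for stronger inhibition and higher numbers for weaker inhibition), and compound 2 (`Cc1cccc(-n2nc(-c3ccccc3)nc2CNc2ccc(C(=O)NO)cc2)c1`) gives 13200 nM there. Among the compounds with values here, compound 2 thus stands within the scatter of compound 1, the only other measured member of the series.

Compound 3 (`O=C(NO)c1ccc(NCc2nc(-c3ccccc3)nn2-c2ccccc2Cl)cc1`) carries 2-chlorophenyl in place of 3-methylphenyl on an aromatic nitrogen, the same place that differs between compound 1 and compound 2. Within the data shown here, one measured step bears on this change: a 1.3-fold higher number from compound 1 to compound 2 (0.10 log units; within the scatter) for the exchange of 4-fluorophenyl for 3-methylphenyl. Neither measured compound carries 2-chlorophenyl, so this single step is thin support. Even so, no change beyond the scatter is expected in this assay, and the estimated step is small (a 1.2-fold lower number from compound 2 to compound 3 (0.08 log units; within the scatter)). For compound 3 the estimated value is 11000 nM (expected range 5000 nM to 25000 nM).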

Compound 3, half-maximal inhibitory concentration: 9630 nM
For compound 3 the middle estimate is 1.1-fold (0.06 log units) above the measured one; low and high end bracket the measured number.
By their numbers in this assay, from the lowest: compounds 3, 1 and 2 (each within the scatter of the next).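

Moving to 2-chlorophenyl on the aromatic nitrogen gives a 1.4-fold lower number from compound 2 to compound 3 (0.14 log units; within the scatter), and against the first member of the series it gives a 1.1-fold lower number from compound 1 to compound 3 (0.04 log units; within the scatter). In this assay, the series now has three aryl groups at this position, 4-fluorophenyl, 3-methylphenyl and 2-chlorophenyl, and every pair lies within the scatter, so the flat result from the first step extends to a chlorine-bearing ring. No supporting data offer an explanation for this flat result.

As far as these compounds go, all three groups are phenyl rings with a single small substituent, so it remains open whether an amine or a carboxylic acid on that ring, or a longer chain in its place, would move the number beyond the scatter. From the compounds shown here alone, the effect of changing the phenyl group elsewhere on the shared core also remains open.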